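The source may report more compounds than this note shows. Statements on the series, on what has been measured and on what is new or still open speak of the compounds shown alone.

In a physicochemical assay for lipophilicity, read by HPLC, at pH 7.4 (on this read-out lower numbers stand for lower lipophilicity and higher numbers for higher lipophilicity), compound 3 `O=C(O)COc1ccc([C@H]2CC[C@]3(CC2)OOC2(O3)C3CC4CC(C3)CC2C4)cc1` gives 2.9. Compound 1 `O=C(O)COc1ccc([C@H]2CC[C@]3(CC2)OOC2(O3)C3CC4CC(C3)CC2C4)cc1Cl` gives 3.2 and compound 2 `O=C(O)c1cc([C@H]2CC[C@]3(CC2)OOC2(O3)C3CC4CC(C3)CC2C4)ccc1O` gives 3, so both lie within the scatter of compound 3. Compound 4 `O=C(O)COc1ccc([C@H]2CC[C@]3(CC2)OOC2(O3)C3CC4CC(C3)CC2C4)cc1C(=O)O` differs from compound 3 by a single change, carboxy in place of hydrogen on an aromatic carbon, ortho to a carboxymethoxy group and meta to a large group.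

Among the measured compounds shown here, only one measured step swaps a group on an aromatic carbon, a number 0.30 log units lower from compound 1 to compound 3 (within the scatter). For the measured compounds named here, it is a weak guide, since chloro is not carboxy and no measured step shows a carboxy group entering. Going by the values given here, compound 2 also carries a carboxy group, but no single-change step links it to compound 3. The expectation therefore rests on the structural change itself, and a drop well beyond the scatter is expected in this assay, namely a number 1.30 log units lower from compound 3 to compound 4 (beyond the scatter). The estimate for compound 4 is 1.6, with an expected range of 0.8 to 2.4.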

Compound 4, distribution coefficient: 1.9
Beside the measured number, compound 4's estimate is 0.30 log units below it; the range from low to high includes it.
By their numbers in this assay, from the lowest: compound 4; then compounds 3, 2 and 1 (each within the scatter of the next).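

In this assay, among the compounds shown here, carboxy in place of hydrogen on an aromatic carbon, ortho to a carboxymethoxy group, gives the first step here that lies beyond the scatter (a number 1.00 log units lower from compound 3 to compound 4 (beyond the scatter)), unlike the earlier exchange of chloro for hydrogen. Compound 4 also stands apart from the other two compounds, through carboxymethyl in place of hydrogen on an oxygen on an aromatic ring (a number 1.10 log units lower from compound 2 to compound 4 (beyond the scatter)) and through carboxy in place of chloro on an aromatic carbon (a number 1.30 log units lower from compound 1 to compound 4 (beyond the scatter)), so it alone combines a carboxy group on the ring with a carboxymethoxy group. Nothing at hand explains the size of these steps.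

Going by these compounds, whether a carboxy group on another ring carbon would give a similar step remains open. So does whether an amine or a carboxamide on this same carbon would.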